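From Methoxy to Propoxy: A Longer Chain on Compound 2

The source may report more compounds than this note shows. Statements on the series, on what has been measured and on what is new or still open speak of the compounds shown alone.

Compound 1 `COc1ccc(C(N)=O)cc1COc1ccc(Cl)c(C)c1` gives 414 mL.min-1.g-1
Compound 2 `COc1ccc(C(N)=O)cc1/C=C/c1ccc(Cl)cc1` gives 110 mL.min-1.g-1
Compound 3 `COc1ccc(C(N)=O)cc1/C=C\c1ccc(Cl)cc1` gives 544 mL.min-1.g-1

In an in vitro ADME assay on microsomes from liver (Mus musculus) for pharmacokinetics, read by LC-MS, with a stated time of 60 min, tested at 5 uM (on this read-out higher numbers stand for fast clearance and lower numbers for slow clearance), compound 2 gives 110 mL.min-1.g-1, the lowest of the three numbers, and both other compounds lie clearly higher. The next compound to be tested is compound 4 `CCCOc1ccc(C(N)=O)cc1/C=C/c1ccc(Cl)cc1`. It differs from compound 2 by ethyl in place of hydrogen on a saturated chain carbon bound to an oxygen on an aromatic ring, which turns the methoxy into a propoxy.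

Within the data shown here, only one measured step connects close relatives here: a 4.9-fold higher number from compound 2 to compound 3 (0.69 log units; beyond the scatter). It comes about due to the fact that compounds 2 and 3 differ only in the configuration as drawn. That step leaves the chain untouched, so it offers no direct guide to the new change and serves only as a gauge of how far numbers can move in this small set. With compound 2 at 110 mL.min-1.g-1 the lowest of the three, a move upward seems more likely than a move downward, though probably a smaller one than that measured step. The expected size and direction in this assay are given by the estimated 2.2-fold higher number from compound 2 to compound 4 (0.34 log units; beyond the scatter). For compound 4 the estimated value is 240 mL.min-1.g-1, with an expected range from 100 mL.min-1.g-1 to 600 mL.min-1.g-1.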

Compound 4, intrinsic clearance in microsomes: 83 mL.min-1.g-1
Estimate against measurement, compound 4: 2.9-fold (0.46 log units) above; the whole stated range lies above it.
By their numbers in this assay, from the lowest: compounds 4 and 2 (each within the scatter of the next); then compounds 1 and 3 (each within the scatter of the next).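

In this assay, swapping methoxy for propoxy gives a 1.3-fold lower number from compound 2 to compound 4 (0.12 log units; within the scatter) and so no change that can be told apart from the spread of repeat measurements. Among these compounds, this is the first view of the chain on that oxygen, as compounds 1, 2 and 3 all carry methoxy there, and it shows that a saturated chain carbon bound to an oxygen on an aromatic ring can take on an added ethyl without a clear move in clearance, in contrast to a 4.9-fold higher number from compound 2 to compound 3 (0.69 log units; beyond the scatter) seen when only the drawn configuration of the double bond changes. Nothing in the information at hand bears on why the number holds steady across this change.

On these data alone, what happens with a still longer chain such as hexyloxy, or with an amine or a carboxylic acid at the end of the chain, stays open. So does whether propoxy would leave the number as steady on the other double-bond form, compound 3, whose value of 544 mL.min-1.g-1 sits far from that of compound 2.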